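Carboxy Replaced by Methanesulfonamido: Expected Agonist Potency

A few compounds are considered here, and "the series" means these few. Any claim that something is new, unique, unknown or untested is made for them only; others in the source may bear on it.

Measured compounds:
compound 1 `COC(=O)c1c(F)cccc1-c1ccc(CCc2ncc(CC(C)(C)C)n2CCC(=O)O)cc1` gives 1 nM
compound 2 `CC(C)(C)Cc1cnc(CCc2ccc(-c3ccccc3C(=O)O)cc2)n1CC(=O)O` gives 897 nM
compound 3 `CC(C)(C)Cc1cnc(CCc2ccc(-c3cccc(F)c3C(=O)O)cc2)n1CCC(=O)O` gives 11 nM

In an assay on cells for agonist activity at Bombesin receptor subtype-3 (Homo sapiens), read by HTRF and inositol phosphate accumulation, with a stated time of 1 h (on this read-out lower numbers stand for an effect already at smaller amounts and higher numbers for an effect only at larger amounts of compound), compound 3 stands second of the three, with compound 1 the nearest and compound 2 the furthest. Among the measured compounds shown here, the one step that changes a single place, an 11-fold higher number from compound 1 to compound 3 (1.04 log units; beyond the scatter), is the only measured step here. Compound 4 `CC(C)(C)Cc1cnc(CCc2ccc(-c3cccc(F)c3C(=O)O)cc2)n1CCNS(C)(=O)=O` differs from compound 3 by methanesulfonamido in place of carboxy on a saturated chain carbon, two bonds along the chain from an aromatic nitrogen. For the measured compounds named here, no measured step touches this exchange; the step from compound 1 to compound 3 alters the same carboxy group, but only by its methyl, and cannot be carried over. For compound 4 a moderate shift toward higher numbers is expected, a 3.6-fold higher number from compound 3 to compound 4 (0.56 log units; beyond the scatter), with wide uncertainty. Compound 4 is therefore estimated at 40 nM, between 8 nM and 200 nM.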

Compound 4, half-maximal effective concentration: 2 nM
The estimate for compound 4 lay 20-fold (1.30 log units) above the measured number; the whole stated range lies above it.
By their numbers in this assay, from the lowest: compounds 1 and 4 (each within the scatter of the next); then compound 3; then compound 2.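

Among the compounds shown here, every earlier compound carried a carboxy group on this chain, so only this exchange shows that the position does not depend on it in this assay: 2-(methanesulfonamido)ethyl in place of 2-carboxyethyl gives a 5.5-fold lower number from compound 3 to compound 4 (0.74 log units; beyond the scatter). The chain end thus accepts a larger group, with five heavy atoms instead of three, and the number still improves. Nothing available explains this gain. Going by these compounds, whether an amide or a tetrazole would serve equally well on this chain remains open. So does whether a longer chain bearing methanesulfonamido would keep the gain.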